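Replacing the bromohydroxyphenyl group of compound 3

This account rests on a few compounds, and the source may have more. Where it says the series, first, only, none or still open, it means among the compounds named here.

Compound 1 `O=C(N/N=C/c1ccc([N+](=O)[O-])cc1)Nc1cc2c(Nc3ccc(F)c(Cl)c3)ncnc2cc1O[C@H]1CCOC1`: 31200 nM
Compound 2 `COc1ccc(/C=N/NC(=O)Nc2cc3c(Nc4ccc(F)c(Cl)c4)ncnc3cc2O[C@H]2CCOC2)c(OC)c1OC`: 25200 nM
Compound 3 `O=C(N/N=C/c1ccc(O)c(Br)c1)Nc1cc2c(Nc3ccc(F)c(Cl)c3)ncnc2cc1O[C@H]1CCOC1`: 4310 nM

In a functional assay on A549 cells (Homo sapiens) for cytotoxicity, read by MTT assay, with a stated time of 72 h (a higher number here means a weaker inhibitor, a lower number a stronger inhibitor), compound 3 (4310 nM) has the lowest of the three numbers, and both of its steps are beyond the scatter: a 5.8-fold lower number from compound 2 to compound 3 (0.77 log units; beyond the scatter) and a 7.2-fold lower number from compound 1 to compound 3 (0.86 log units; beyond the scatter) are modest. The two higher values do not separate, since a 1.2-fold lower number from compound 1 to compound 2 (0.09 log units; within the scatter) lies within the scatter.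

Next is compound 4 `CCN(CC)c1ccc(/C=N/NC(=O)Nc2cc3c(Nc4ccc(F)c(Cl)c4)ncnc3cc2O[C@H]2CCOC2)c(O)c1`, with 4-(diethylamino)-2-hydroxyphenyl in place of 3-bromo-4-hydroxyphenyl on a carbon with a double bond to nitrogen. Going by the values given here, all three measured steps change this same place, so they are the only guide. Both replacements of another group by 3-bromo-4-hydroxyphenyl lowered the number, as a 5.8-fold lower number from compound 2 to compound 3 (0.77 log units; beyond the scatter) and a 7.2-fold lower number from compound 1 to compound 3 (0.86 log units; beyond the scatter) show, and compound 4 gives that group up. Among the compounds with values here, its entering group keeps a hydroxy, but no measured compound carries a diethylamino group, so the size remains uncertain.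

The expected change in this assay is modest and upward, estimated at a 2.3-fold higher number from compound 3 to compound 4 (0.37 log units; beyond the scatter) (with a wide margin). For compound 4 the estimated value is 10000 nM (expected range 3000 nM to 30000 nM).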

Compound 4, half-maximal inhibitory concentration: 15700 nM
Beside the measured number, compound 4's estimate is 1.6-fold (0.20 log units) below it; measured number inside the range.
By their numbers in this assay, from the lowest: compound 3; then compounds 4, 2 and 1 (each within the scatter of the next).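

In this assay, the change at this position shows that a hydroxy on the entering group is not enough to keep the low number of compound 3: 4-(diethylamino)-2-hydroxyphenyl in place of 3-bromo-4-hydroxyphenyl gives a 3.6-fold higher number from compound 3 to compound 4 (0.56 log units; beyond the scatter). Against the other two groups on the carbon with a double bond to nitrogen, the result is a 1.6-fold lower number from compound 2 to compound 4 (0.21 log units; within the scatter) and a 2.0-fold lower number from compound 1 to compound 4 (0.30 log units; within the scatter), both within the scatter, so compound 4 does not separate from compound 1 or compound 2, and compound 3 now stands apart from all three. Nothing on hand bears on why the number changes with these groups.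

The step from compound 3 to compound 4 alters the bromine, the place of the hydroxy and the diethylamino group together, so the compounds shown cannot assign the low number of compound 3 to any one of them. A hydroxyphenyl without bromine, a bromophenyl without hydroxy, or a smaller dimethylamino group on the same ring would separate these contributions.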